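Benzyl removal at the amide nitrogen of compound 3

The compounds below may be only part of what the source reports. "The series", "measured", "known", "first", "only" and "open" are said of these compounds alone.

Among the measured compounds shown here, compound 3 `O=C(Nc1ccc(-n2ccc3nc(C(=O)NCc4ccccc4)ccc32)cc1)Nc1ccc(Cl)c(C(F)(F)F)c1` gives 3000 nM in an ADME assay on HS27 cells (Homo sapiens) for cytotoxicity, read by MTT assay (a lower number here means a stronger inhibitor, a higher number a weaker inhibitor), and is the only compound of the three with a number rather than a limit. Compound 1 `O=C(Nc1ccc(-n2ccc3nc(C(=O)NCc4ccccc4)ccc32)cc1)Nc1cccc(Cl)c1Cl` sits at the assay limit, > 10000 nM. Compound 2 `O=C(Nc1ccc(-n2ccc3nc(C(=O)NCc4ccccc4)ccc32)cc1)c1cccc(C(F)(F)F)c1` likewise sits at the assay limit, > 10000 nM. The measured steps all change the group on the urea or amide carbonyl: an at least 3.3-fold lower number from compound 1 to compound 3 (0.52 log units; beyond the scatter) and an at least 3.3-fold lower number from compound 2 to compound 3 (0.52 log units; beyond the scatter), with the limit of > 10000 nM in this assay, at which 2 of the 3 values shown sit, leaving the step from compound 1 to compound 2 unreadable. Compound 4 `NC(=O)c1ccc2c(ccn2-c2ccc(NC(=O)Nc3ccc(Cl)c(C(F)(F)F)c3)cc2)n1` differs from compound 3 at a different place: hydrogen in place of benzyl on an amide-type nitrogen. For the measured compounds named here, no measured step touches this amide nitrogen, so no direction is read from the data; the expected step is a 1.3-fold higher number from compound 3 to compound 4 (0.12 log units; within the scatter), within the scatter. Compound 4 is therefore estimated at 4000 nM, in the range 1500 nM to 12000 nM.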

Compound 4, half-maximal inhibitory concentration: > 10000 nM
Compound 4 was reported as a limit (the forecaster's own chance of this, stated with the estimate: 35%); at least 2.5-fold (0.39 log units) between middle value and limit.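

Hydrogen in place of benzyl on the amide-type nitrogen gives an at least 3.3-fold higher number from compound 3 to compound 4 (0.52 log units; beyond the scatter) in this assay as the only reading at this position. The number therefore responds to a change at this nitrogen as well as to the earlier changes on the urea or amide carbonyl. Compound 4 is reported as a limit, so the step has only a lower bound: the limit of > 10000 nM in this assay, at which 3 of the 4 values shown sit.

On these data alone, the true size of the step stays open. Also open, as far as these compounds go, is whether a methyl or cyclohexylmethyl group on this nitrogen would keep the number of compound 3.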